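Ortho versus para chlorine on the benzylsulfanyl arm

This account rests on a few compounds, and the source may have more. Where it says the series, first, only, none or still open, it means among the compounds named here.

Compound 1 `CC1=C(C(=O)Nc2ccc(Br)cc2)C(c2ccc(Cl)cc2Cl)N=C(SCc2ccccc2)N1`: 11.3%
Compound 2 `CC1=C(C(=O)Nc2ccc(Br)cc2)C(c2ccc(Cl)cc2Cl)N=C(SCc2ccc(Cl)cc2)N1`: 25.8%
Compound 3 `CC1=C(C(=O)Nc2ccc([N+](=O)[O-])cc2)C(c2ccc(Br)cc2)N=C(SCc2ccccc2)N1`: 21.1%

In a functional assay on the whole organism (artery, strain albino) with Rattus norvegicus as the target, with a stated time of 720 min, at a dose of 10 mg/kg by the oral route (a lower number here means less inhibition, a higher number more inhibition at the dose given (going by the name of the read-out)), compound 1 gives 11.3%, compound 2 gives 25.8% and compound 3 gives 21.1%. From compound 1 to compound 2 the change is chloro in place of hydrogen on an aromatic carbon, and the step is a number 14.5 percentage points higher from compound 1 to compound 2 (beyond the scatter). Compound 3 and compound 1 share a core whose difference is not broken down here. Compound 4 `CC1=C(C(=O)Nc2ccc([N+](=O)[O-])cc2)C(c2ccc(Br)cc2)N=C(SCc2ccccc2Cl)N1` differs from compound 3 by chloro in place of hydrogen on an aromatic carbon, which is the same kind of change as that from compound 1 to compound 2, but the place differs: para to a large group there, ortho to a large group here. The step is therefore expected to be smaller or similar, resting only on compound 2 having given 25.8% after the para change; in this assay the step from compound 3 to compound 4 is expected to be a number 8.9 percentage points higher from compound 3 to compound 4 (within the scatter). Compound 4 is estimated at 30%, between 15% and 45%.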

Compound 4, a percentage reported as inhibition, in the whole organism at one dose (the size of the read-out at that dose, not a potency): 6.7%
Compound 4: middle estimate off by 23.3 percentage points, on the high side; measured number outside the range, below it.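

In this assay, chloro in place of hydrogen on an aromatic carbon gave a number 14.4 percentage points lower from compound 3 to compound 4 (beyond the scatter), so the gain seen on the other core did not carry over. Set side by side, the two steps point in opposite directions: the same change on two cores in this assay, a number 14.5 percentage points higher (beyond the scatter) from compound 1 to compound 2 and a number 14.4 percentage points lower (beyond the scatter) from compound 3 to compound 4, 28.9 percentage points apart, beyond the scatter of two such steps This shows that the name of the change alone does not predict its result across these cores, but it does not show what separates the two results: the core and the place of the chloro group both differ between the pairs, and each result rests on a single pair.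

From the compounds shown here alone, it remains open how (2-chlorobenzyl)sulfanyl would behave on the core of compound 1. Also open, going by these compounds, is whether a fluoro or methoxy group in place of the chloro group of compound 4 would give a similar result.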